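Swapping the bicyclic group on compound 2

The source may hold more compounds than are shown below. What is called first, only, known or untested is meant among the compounds shown, and "the series" means these compounds.

The three measured compounds share one core. Compound 1 `CC(=O)N1CCc2c(c(-c3ccc(C(F)(F)F)cc3)nn2CC(O)CN2CCC(c3csc4cc(F)ccc34)CC2)C1` carries an acetyl on the ring amine, compound 2 `CS(=O)(=O)N1CCc2c(c(-c3ccc(C(F)(F)F)cc3)nn2CC(O)CN2CCC(c3csc4cc(F)ccc34)CC2)C1` a methylsulfonyl, and compound 3 `COC(=O)c1sc2cc(F)ccc2c1C1CCN(CC(O)Cn2nc(-c3ccc(C(F)(F)F)cc3)c3c2CCN(S(C)(=O)=O)C3)CC1` adds a methoxycarbonyl on an aromatic carbon. In an assay on isolated protein for inhibition of cathepsin S (Homo sapiens) (a higher number here means a weaker inhibitor, a lower number a stronger inhibitor), compound 1 gives 290 nM, compound 2 gives 180 nM and compound 3 gives 130 nM. Compound 2 stands second highest of the three numbers; the nearer step is a 1.4-fold lower number from compound 2 to compound 3 (0.14 log units; within the scatter) and the further step is a 1.6-fold lower number from compound 1 to compound 2 (0.21 log units; within the scatter). Both lie within the scatter, so on these numbers the three compounds cannot be told apart.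

Compound 4 `COc1ccc2[nH]cc(C3CCN(CC(O)Cn4nc(-c5ccc(C(F)(F)F)cc5)c5c4CCN(S(C)(=O)=O)C5)CC3)c2c1` differs from compound 2 by 5-methoxy-1H-indol-3-yl in place of 6-fluoro-1-benzothiophen-3-yl on a saturated ring carbon. Neither measured step touches this part of the molecule: one changed the group on the ring amine, the other added a group on an aromatic carbon, and both stayed within the scatter. Within the data shown here, no measured step therefore bears directly on the exchange, and the data give no direction for it. The working expectation in this assay is a step of a 1.2-fold higher number from compound 2 to compound 4 (0.09 log units; within the scatter), expected to stay within the scatter but carrying wide uncertainty. Compound 4 is accordingly estimated at 220 nM, with a range from 70 nM to 700 nM.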

Compound 4, half-maximal inhibitory concentration: 29 nM
The estimate for compound 4 lay 7.6-fold (0.88 log units) above the measured number, and the stated range ends above it.
By their numbers in this assay, from the lowest: compound 4; then compounds 3, 2 and 1 (each within the scatter of the next, the first and the last beyond it).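

In this assay, among these compounds, the group on the saturated ring carbon, three ring bonds from the ring nitrogen, is the first place where a single change reaches beyond the scatter, with a 6.2-fold lower number from compound 2 to compound 4 (0.79 log units; beyond the scatter) as the step, whereas the changes on the ring amine and on the aromatic carbon did not. So this position responds to the exchange of 6-fluoro-1-benzothiophen-3-yl for 5-methoxy-1H-indol-3-yl, an exchange that keeps the same two ring types and the 1 hydrogen-bond acceptor but goes from 0 hydrogen-bond donors to 1 and replaces fluorine and sulfur with nitrogen and oxygen. No measurement at hand accounts for the step, and several features change in this one exchange, so it cannot be assigned to any one of them.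

Still open, going by these compounds, is whether the step belongs to the indole itself or to its methoxy group, which an indole carrying plain hydrogen, fluorine or a hydroxyl in place of the methoxy would separate. Also open, on these data alone, is whether the same exchange holds with an acetyl on the ring amine, as in compound 1, or with an amine or a carboxylic acid on the indole.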